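Removing one acetyl from compound 2

The source may hold more compounds than are shown below. What is called first, only, known or untested is meant among the compounds shown, and "the series" means these compounds.

This account concerns two flavone-type compounds tested in a functional assay on SGC-7901 cells (Homo sapiens) for inhibition (a lower number here means a stronger inhibitor, a higher number a weaker inhibitor), and a third one not yet measured. Compound 1 `COc1cc(OC)c2c(=O)cc(-c3ccccc3)oc2c1C(F)(F)F` gives 5900 nM in this assay. Compound 2 `CC(=O)Oc1cc(OC(C)=O)c2c(=O)cc(-c3ccccc3)oc2c1` gives 4500 nM in this assay, and the two numbers lie within the usual scatter of each other, so neither compound can be set apart from the other on these data.

Compound 3 `CC(=O)Oc1cc(O)c2c(=O)cc(-c3ccccc3)oc2c1` differs from compound 2 in one place: hydrogen in place of acetyl on an oxygen on an aromatic ring. Within the data shown here, no pair of measured compounds shows this same change, so the data give no step to read its size from. Without such a step, compound 3 is expected to stay close to compound 2, with a step from compound 2 to compound 3 of about a 1.1-fold lower number from compound 2 to compound 3 (0.05 log units; within the scatter), not beyond the scatter. Compound 3 is therefore estimated at 4000 nM in this assay, within a range from 1500 nM to 12000 nM.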

Compound 3, half-maximal inhibitory concentration: 3600 nM
Compound 3: middle estimate off by 1.1-fold (0.05 log units), on the high side; measured number inside the range.
By their numbers in this assay, from the lowest: compounds 3, 2 and 1 (each within the scatter of the next).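

Among these compounds, the step of a 1.3-fold lower number from compound 2 to compound 3 (0.10 log units; within the scatter) is the first direct reading of the change from acetoxy to hydroxy in this assay, since the earlier compounds offered no pair that differed in one place. It shows that, at this oxygen on an aromatic ring, hydrogen can stand in place of acetyl without the number moving beyond the usual scatter, although this rests on a single pair. No measurement at hand offers an explanation for this result.

The compounds shown leave open whether removing the remaining acetyl from compound 3 would also leave the number within the scatter. They also leave open whether a longer acyl chain or an amine-bearing chain on this oxygen would give a step beyond it.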